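From an ortho-chlorophenyl sulfone to a para-fluorophenyl sulfone

The source may report more compounds than this note shows. Statements on the series, on what has been measured and on what is new or still open speak of the compounds shown alone.

Measured compounds:
compound 1 `CN1CCN(c2ccc3[nH]nc(S(=O)(=O)c4ccccc4Cl)c3c2)CC1` — 4 nM
compound 2 `O=S(=O)(c1cccc(F)c1)c1n[nH]c2cccc(N3CCNCC3)c12` — 134 nM

Of the compounds shown here, two have been measured in an assay on HeLa cells for displacement of a labelled ligand from 5-hydroxytryptamine receptor 6 (Homo sapiens); on this read-out lower numbers stand for stronger inhibition and higher numbers for weaker inhibition. Compound 1, built as `CN1CCN(c2ccc3[nH]nc(S(=O)(=O)c4ccccc4Cl)c3c2)CC1`, gives 4 nM in this assay, the lowest of the two numbers. Compound 2, built as `O=S(=O)(c1cccc(F)c1)c1n[nH]c2cccc(N3CCNCC3)c12`, gives 134 nM in this assay, a higher number that lies well beyond the scatter of repeated measurement. The two differ in more than one place, so the gap between them is not assigned to any single change.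

Compound 3, built as `CN1CCN(c2ccc3[nH]nc(S(=O)(=O)c4ccc(F)cc4)c3c2)CC1`, has not yet been measured. It differs from compound 1 in one place: 4-fluorophenyl in place of 2-chlorophenyl on a sulfonyl sulfur. For the measured compounds named here, no measured pair in this set isolates such a change, so the size of the step is uncertain. The account expects the step of a 2.5-fold higher number from compound 1 to compound 3 (0.40 log units; beyond the scatter) to be modest, leaning toward a somewhat higher number, that is weaker inhibition, though a result within the scatter would not surprise. Compound 3 is therefore estimated at 10 nM in this assay, with a range from 3 nM to 40 nM.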

Compound 3, inhibition constant: 5.2 nM
For compound 3 the middle estimate is 1.9-fold (0.28 log units) above the measured one; low and high end bracket the measured number.
By their numbers in this assay, from the lowest: compounds 1 and 3 (each within the scatter of the next); then compound 2.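

For the compounds shown here, the step of a 1.3-fold higher number from compound 1 to compound 3 (0.11 log units; within the scatter) in this assay gives the first single-place comparison in this set, and it shows that 4-fluorophenyl can take the place of 2-chlorophenyl on a sulfonyl sulfur with no difference that can be told from the scatter. Within this pair, neither the identity of the halogen nor its numbered place on the phenyl ring separates the two compounds on this read-out, although the change alters both at once and so cannot show what either alteration does alone. Nothing given here bears on why the two groups read alike.

The pair leaves open whether 2-fluorophenyl, 4-chlorophenyl or plain unsubstituted phenyl would also fall within the scatter of compound 1, which would separate the halogen from its place on the ring. It also leaves open whether this sulfonyl sulfur would accept something further from these groups, such as a pyridine ring, a naphthyl group or a saturated cyclohexyl ring, in place of the halogenated phenyl.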